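A few compounds are considered here, and "the series" means these few. Any claim that something is new, unique, unknown or untested is made for them only; others in the source may bear on it.

Measured compounds:
compound 1 `CC(C)(NC(=O)c1cc(F)cc2cc(-c3ccc(Cl)cc3)oc12)c1nnn[nH]1`: 275 nM
compound 2 `CC(C)(NC(=O)c1cccc2cc(-c3ccc(Cl)cc3)oc12)C(=O)O`: 1030 nM
compound 3 `CC(C)(NC(=O)c1cccc2c(Br)c(-c3ccc(Cl)cc3)oc12)C(=O)O`: 1760 nM

All three were run in an assay on isolated protein for inhibition of endoplasmic reticulum aminopeptidase 1 (Homo sapiens), with stated times of 15 min and 20 min; a lower number here means a stronger inhibitor, a higher number a weaker inhibitor. Compound 1 stands lowest of the three; compound 2 is nearest and compound 3 furthest, both beyond the scatter. Going by the values given here, the one single-point step measured so far is a 1.7-fold higher number from compound 2 to compound 3 (0.23 log units; within the scatter), which lies within the scatter.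

Compound 4 `O=C(NC1(C(=O)O)CC1)c1cc(F)cc2cc(-c3ccc(Cl)cc3)oc12` is not yet measured. It differs from compound 1 by 1-carboxycyclopropyl in place of 1-(1H-tetrazol-5-yl)-1-methylethyl on an amide-type nitrogen. Among the compounds with values here, no measured step covers this change. Compound 1 and compound 2 differ at this same amide-type nitrogen, tetrazole against carboxylic acid, but also in the fluoro on the core, so their gap cannot be assigned to one change alone; the two values together only suggest that a carboxylic acid here tends to sit at a higher number than the tetrazole of compound 1. Within the data shown here, the cyclopropyl in place of the two methyls has no counterpart among the measured compounds. The step from compound 1 to compound 4 in this assay is therefore expected to run towards a higher number, of moderate size, about a 2.5-fold higher number from compound 1 to compound 4 (0.41 log units; beyond the scatter). Compound 4 is estimated at 700 nM, with a range from 250 nM to 2000 nM.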

Compound 4, half-maximal inhibitory concentration: 1120 nM
The estimate for compound 4 lay 1.6-fold (0.20 log units) below the measured number; low and high end bracket the measured number.
By their numbers in this assay, from the lowest: compound 1; then compounds 2, 4 and 3 (each within the scatter of the next).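

In this assay, with the shared core held constant, 1-carboxycyclopropyl in place of 1-(1H-tetrazol-5-yl)-1-methylethyl on an amide-type nitrogen gives a 4.1-fold higher number from compound 1 to compound 4 (0.61 log units; beyond the scatter) and so shows that the group at this position can move the number beyond the scatter. Going by these compounds alone, this is the first step confined to this position: the gap between compound 1 and compound 2 also carried the fluoro difference on the core, and the only earlier single-place step was a bromo on an aromatic carbon, which stayed within the scatter. No measurement available here accounts for the size or direction of this step.

The change swaps the tetrazole for a carboxylic acid and also brings in the cyclopropane ring, so the compounds shown leave open how much of the step belongs to each part; a pair changing only one of them would separate the two. Also open, on these data alone, is how this position would respond to a hydroxamic acid, or to a cyclobutane ring carrying the carboxylic acid.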